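Swapping a Sulfonyl Group for a Thiophene Amide

This account rests on a few compounds, and the source may have more. Where it says the series, first, only, none or still open, it means among the compounds named here.

Measured compounds:
Compound 1, `CC(C)=CCC1Cc2c(OCCCNS(=O)(=O)c3ccc(C(F)(F)F)cc3)cc(=O)n(CCCO)c2CC1(C)C`: 0%
Compound 2, `CC(C)=CCC1Cc2c(OCCCNS(=O)(=O)c3ccc(Cl)cc3)cc(=O)n(CCCO)c2CC1(C)C`: 9.8%

In a functional assay on PANC-1 cells (Homo sapiens) for inhibition, read by MTT assay, with a stated time of 24 h, tested at 10 uM (on this read-out higher numbers stand for more inhibition at the one concentration tested (going by the name of the read-out) and lower numbers for less inhibition), compound 1 gives 0%, and compound 2 gives 9.8%. Compound 2 carries the larger of the two numbers, but the step of a number 9.8 percentage points higher from compound 1 to compound 2 (within the scatter) is within the scatter, so the two compounds cannot be told apart on this read-out. Compound 3, `CC(C)=CCC1Cc2c(OCCCNC(=O)c3cccs3)cc(=O)n(CCCO)c2CC1(C)C`, differs from compound 2 by (thiophen-2-yl)carbonyl in place of (4-chlorophenyl)sulfonyl on an amine nitrogen. For the measured compounds named here, the only measured step, a number 9.8 percentage points higher from compound 1 to compound 2 (within the scatter), changes a group on the aromatic ring of the sulfonyl part and is within the scatter; no measured step touches the exchange of the whole sulfonyl group for a carbonyl group with a thiophene ring. Nothing in the data therefore points to a step beyond the scatter in either direction. The estimated step is a number 3.8 percentage points lower from compound 2 to compound 3 (within the scatter). Compound 3 is expected to give about 6%, with a range from 0% to 22%.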

Compound 3, a percentage reported as inhibition, at one concentration (the size of the read-out at that concentration, not a potency): 5.6%
Beside the measured number, compound 3's estimate is 0.4 percentage points above it; the range from low to high includes it.
By their numbers in this assay, from the lowest: compounds 1, 3 and 2 (each within the scatter of the next).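

In this assay, the earlier step changed only a group on the aromatic ring, whereas this one replaces the whole (4-chlorophenyl)sulfonyl on the amine nitrogen and gives a number 4.2 percentage points lower from compound 2 to compound 3 (within the scatter). Even an exchange of both the sulfonyl link and the six-membered ring for a carbonyl link and a five-membered ring with one hetero atom therefore leaves the two compounds indistinguishable on this read-out. No supporting measurement bears on this result.

Both parts changed together, so the effect of the carbonyl link cannot be separated from that of the thiophene ring. On these data alone, a benzoyl group on the same nitrogen would pair the carbonyl with a six-membered carbon ring, and whether that, a carboxylic acid or a longer chain there would give a step beyond the scatter remains open.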